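The compounds below may be only part of what the source reports. "The series", "measured", "known", "first", "only" and "open" are said of these compounds alone.

Measured so far in a functional assay on the whole organism (strain albino) for inhibition, with Rattus norvegicus as the target, read by paw edema, with stated times of 30 min and 3 h, at a dose of 5 mg/kg by the oral route; on this read-out lower numbers stand for less inhibition and higher numbers for more inhibition at the one dose given (going by the name of the read-out):

Compound 1, `Nc1nc(CC(=O)O)n[nH]1` — 48.1%
Compound 2, `CCOC(=O)Cc1nc(N)n(C(=O)c2ccccc2)n1` — 57.5%
Compound 3, `CCOC(=O)Cc1nc(N)n(C(=O)c2ccc(Br)cc2)n1` — 64.1%

Among these three numbers compound 2 stands second highest. Within the data shown here, its nearest neighbour is compound 3, and the step of a number 6.6 percentage points higher from compound 2 to compound 3 (within the scatter) is the only single change measured here. Compound 1 lies furthest away, but the gap between compound 1 and compound 2 also stays within the usual scatter of this assay, so the three measured compounds cannot be told apart with confidence.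

Compound 4, `CCOC(=O)Cc1nc(N)n(C(=O)c2ccc(OC)cc2)n1`, is the next compound to be measured. It differs from compound 2 in one place: methoxy in place of hydrogen on an aromatic carbon. Among the measured compounds shown here, the one measured step that bears on this change is the one from compound 2 to compound 3, where a group entered at the same kind of position and the read-out moved within the scatter. For the measured compounds named here, there is no measured example of a methoxy group on this ring, so the expectation rests on that single step alone.

The expected outcome is therefore a step of a number 2.5 percentage points higher from compound 2 to compound 4 (within the scatter) that stays within the scatter, without a clear direction. For compound 4 the estimate in this assay is 60%, with an expected range from 45% to 75%.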

Compound 4, a percentage reported as inhibition, in the whole organism at one dose (the size of the read-out at that dose, not a potency): 60%
Compound 4: middle estimate and measured number agree at the digits printed, and the stated range covers the measured number.
By their numbers in this assay, from the lowest: compounds 1, 2, 4 and 3 (each within the scatter of the next, the first and the last beyond it).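

In this assay, methoxy in place of hydrogen on an aromatic carbon, para to a large group, gives a number 2.5 percentage points higher from compound 2 to compound 4 (within the scatter) and so adds a second substituent at this position whose step does not leave the scatter. Exchanging the two substituents at that same place gives a number 4.1 percentage points lower from compound 3 to compound 4 (within the scatter), which means that bromo and methoxy, two quite different groups, cannot be told apart by this read-out, and neither can be told apart from hydrogen. No measurement at hand bears on what lies behind these numbers.

What the compounds shown leave open is whether any group at this position can move the read-out beyond the scatter, for instance an amine, a carboxylic acid or a longer chain such as butoxy. Each number also comes from a single dose, so these compounds do not show whether hydrogen, bromo and methoxy would still be indistinguishable at other doses, where a real difference between them might appear.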